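The source may hold more compounds than are shown below. What is called first, only, known or untested is meant among the compounds shown, and "the series" means these compounds.

Of the compounds shown here, two have been measured so far. Compound 1 `CCCC(=O)C1=C(C)NC(=O)NC1c1ccco1` and compound 2 `CC1=C(C(=O)C2CC2)C(c2cccs2)NC(=O)N1` were both tested in an assay on membranes from HeLa cells for displacement of a labelled ligand from adenosine receptor A3 (Homo sapiens), read by scintillation counting, with a stated time of 180 min, tested at 1 uM; on this read-out lower numbers stand for less inhibition and higher numbers for more inhibition at the one concentration tested (going by the name of the read-out). Compound 1 gives 1%, and compound 2 gives 15% in this assay. Compound 2 therefore stands highest of the two numbers, and its nearest neighbour, compound 1, lies a number of percentage points lower, a gap beyond the usual scatter. Since compound 1 and compound 2 differ in more than one place, their two values show only this gap and nothing more.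

Compound 3 `CCCC(=O)C1=C(C)NC(=O)NC1c1cccs1` has not yet been measured. It differs from compound 2 in one place: propyl in place of cyclopropyl on a carbonyl carbon. Among the compounds with values here, no step between measured compounds isolates this change, so the expected size of the step in this assay is uncertain; a modest fall is expected, one that may stay within the scatter, so that the step of a number 7 percentage points lower from compound 2 to compound 3 (within the scatter) is estimated as small and downward. Compound 3 is expected to give about 8%, within a range from 0% to 20%.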

Compound 3, a percentage reported as inhibition, at one concentration (the size of the read-out at that concentration, not a potency): 2%
The estimate for compound 3 lay 6 percentage points above the measured number; measured number inside the range.
By their numbers in this assay, from the lowest: compounds 1 and 3 (each within the scatter of the next); then compound 2.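

In this assay, within the data shown here, the group on the carbonyl carbon now has a measured effect: the change from cyclopropyl to propyl gives a number 13 percentage points lower from compound 2 to compound 3 (beyond the scatter) and is the first comparison of compounds differing only at this position. The other single change, thiophen-2-yl in place of furan-2-yl on a saturated ring carbon, gives a number 1 percentage points higher from compound 1 to compound 3 (within the scatter) so with propyl on the carbonyl carbon, these two rings do not separate the compounds. Nothing available explains either step.

As far as these compounds go, whether the cyclopropyl-to-propyl step would recur with furan-2-yl on the saturated ring carbon remains open. So does how a cyclobutyl, a phenyl or a longer chain on the carbonyl carbon would read in this assay and whether any such group would surpass compound 2, which gives 15% in this single-concentration test.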